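The source may hold more compounds than are shown below. What is called first, only, known or untested is meant among the compounds shown, and "the series" means these compounds.

Measured so far in a functional assay on KB cells (Homo sapiens) for inhibition, with a stated time of 72 h; a higher number here means a weaker inhibitor, a lower number a stronger inhibitor:
compound 1 `CCCOc1c(O)cc2oc(-c3ccccc3)cc(=O)c2c1O`: 58900 nM
compound 2 `CCCOc1cc2oc(-c3ccccc3)cc(=O)c2c(O)c1OCCC`: > 100000 nM, a limit of the assay and not a number

Compound 2 stands only at the limit of > 100000 nM in this assay, at which 1 of the 2 values shown sits. Its true position is therefore open on the upper side.

The next compound is compound 3 `CCCOc1c(OC)cc2oc(-c3ccccc3)cc(=O)c2c1O`. The change is hydrogen in place of ethyl on a saturated chain carbon bound to an oxygen on an aromatic ring, which is the same as propoxy to methoxy. The oxygen concerned carries hydrogen in compound 1 and propyl in compound 2, so compound 3 has a group on that oxygen that is shorter than propyl.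

Among the compounds with values here, only one measured step bears on this: an at least 1.6-fold higher number from compound 1 to compound 2 (0.22 log units; that floor lies within the scatter). It concerns the same oxygen, but it is a floor and not a size. The nearest true number is that of compound 1 at 58900 nM, so an expectation close to that number is the only one these data support. In this assay the expected step is an at least 1.6-fold lower number from compound 2 to compound 3 (0.22 log units; that floor lies within the scatter), toward a lower number or no change beyond the scatter, and a result at the limit remains possible. Compound 3 is estimated at 60000 nM, with an expected range of 25000 nM to 100000 nM.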

Compound 3, half-maximal inhibitory concentration: > 100000 nM
Compound 3 was reported as a limit (the forecaster's own chance of this, stated with the estimate: 35%); middle value at least 1.6-fold (0.22 log units) away from the limit.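

In this assay compound 3 gives > 100000 nM, a limit of the assay and not a number. Shortening propyl to methyl on this oxygen therefore does not bring back a readable value, and methyl in place of hydrogen there gives an at least 1.6-fold higher number from compound 1 to compound 3 (0.22 log units; that floor lies within the scatter), so neither methyl nor propyl can yet be said to shift the value beyond the scatter. Within the data shown here, compound 1, with hydrogen on this oxygen, remains the only compound of the three with a true number, and the step between the two compounds at the limit cannot be read: the limit of > 100000 nM in this assay, at which 2 of the 3 values shown sit.

Still open, going by these compounds, is how far compound 2 and compound 3 truly lie beyond the limit, and so whether propyl and methyl differ at all in this assay. Also open, on these data alone, is whether a longer chain on this oxygen, or a chain ending in an amine or a carboxylic acid, would give a true number, and on which side of compound 1 that number would fall.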